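The source may report more compounds than this note shows. Statements on the series, on what has been measured and on what is new or still open speak of the compounds shown alone.

Within the data shown here, compound 2, `CCCCCCCCCCCCCCN(N)C(=O)OC(C)(C)C`, is the only compound here with an actual number in a functional assay on HeLa cells (Homo sapiens) for cytotoxicity, with a stated time of 72 h (on this read-out lower numbers stand for higher toxicity in this test and higher numbers for lower toxicity in this test), where compound 2 gives 96500 nM. Compound 1, `CCCCCCCCCCCCCCN(NC(=O)COC)C(=O)CCCCCCCCC`, which also bears the (methoxymethyl)carbonyl group on its hydrazide, is reported in this assay only as a limit, > 110000 nM. Compound 3, `CCCCCCCCCCCCCCN(NC(=O)COC)C(=O)OC(C)(C)C`, carries (methoxymethyl)carbonyl in place of hydrogen on an amine nitrogen. Among the measured compounds shown here, no measured pair shows this change, so its size is unknown, and an expectation can rest only on compound 1 reaching its limit. The expected step is a 1.1-fold higher number from compound 2 to compound 3 (0.06 log units; within the scatter), small and toward weaker toxicity. Compound 3 is therefore estimated at 110000 nM, within a range from 50000 nM to 250000 nM.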

Compound 3, half-maximal cytotoxic concentration: 41900 nM
For compound 3 the middle estimate is 2.6-fold (0.42 log units) above the measured one; the whole stated range lies above it.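

In this assay, (methoxymethyl)carbonyl in place of hydrogen on an amine nitrogen gives a 2.3-fold lower number from compound 2 to compound 3 (0.36 log units; beyond the scatter), so acylating this nitrogen moves the read-out toward higher toxicity in this test. With that group kept, tert-butoxy in place of nonyl on a carbonyl carbon gives an at least 2.6-fold lower number from compound 1 to compound 3 (0.41 log units; beyond the scatter). This second step is only a bound, as compound 1 is reported as a limit: the limit of > 110000 nM in this assay, at which 1 of the 3 values shown sits.

Going by these compounds, whether a smaller acetyl group or a benzoyl group on this amine nitrogen gives a similar step remains open. So does the outcome of a carboxylic acid in place of the methoxy group.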